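The source may report more compounds than this note shows. Statements on the series, on what has been measured and on what is new or still open speak of the compounds shown alone.

Compound 1 `CS(=O)(=O)c1ccc(F)cc1NCC1=NCCN1` gives < 5020 nM in an assay on CHO cells for binding affinity to Alpha-2C adrenergic receptor (Homo sapiens), read by radioligand binding; a lower number here means a stronger inhibitor, a higher number a weaker inhibitor; this value is a limit of the assay, not a number.
Compound 2 `CSc1ccc(F)cc1NCC1=NCCN1` gives 115 nM in this assay.
Compound 3 `CSc1cc(F)ccc1NCC1=NCCN1` gives 219 nM in this assay.

Compound 2 holds the lowest of the two numbers in this assay; compound 3 stands a step away that lies within the scatter, so no order between the two is claimed. The step that the limit leaves unreadable from compound 1 to compound 2 cannot be sized due to the limit of < 5020 nM in this assay, at which 1 of the 3 values shown sits.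

Compound 4 `CSc1ccc(Cl)cc1NCC1=NCCN1` differs from compound 2 by chloro in place of fluoro on an aromatic carbon. Within the data shown here, none of the measured steps exchanges one halogen for another, and the single measured step is unreadable, so nothing here bears directly on this change. A step not beyond the scatter in this assay is therefore expected. Compound 4 is estimated at 100 nM, with a range from 40 nM to 300 nM. The expected step is a 1.2-fold lower number from compound 2 to compound 4 (0.06 log units; within the scatter).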

Compound 4, inhibition constant: 170 nM
For compound 4 the middle estimate is 1.7-fold (0.23 log units) below the measured one; the range from low to high includes it.
By their numbers in this assay, from the lowest: compounds 2, 4 and 3 (each within the scatter of the next).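

In this assay, chloro in place of fluoro on the aromatic carbon para to the methylsulfanyl group gives a 1.5-fold higher number from compound 2 to compound 4 (0.17 log units; within the scatter). Among these compounds, this is the only readable step, and it shows that this position accepts either halogen with no order between the two compounds. The other single-place step cannot be read: the limit of < 5020 nM in this assay, at which 1 of the 4 values shown sits.

Going by these compounds, whether the position tolerates anything other than a halogen stays open, for example a methoxy group, an amine or a nitrile. Also open, on these data alone, is whether bromo would fit the same picture.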